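Acetyl on the aromatic nitrogen: notes on compound 3

This account rests on a few compounds, and the source may have more. Where it says the series, first, only, none or still open, it means among the compounds named here.

Measured so far:
compound 1 `CSc1ccc(/C(C)=N/OCC(=O)O)cc1` gives < 20% in a functional assay on the whole organism for inhibition, with Rattus norvegicus as the target, read by paw edema, with stated times of 1 h and 3 h, at a dose of 50 mg/kg by the oral route; on this read-out lower numbers stand for less inhibition and higher numbers for more inhibition at the one dose given (going by the name of the read-out); this is a limit of the assay, not a number.
compound 2 `C/C(=N\OCC(=O)O)c1ccc(N)cc1` gives 20% in this assay.

Compound 2 carries the only number shown in this assay; the other entry is a limit. Among the compounds with values here, the one step between measured compounds, a number no lower from compound 1 to compound 2 (the limit leaves the size open), exchanges amino for methylsulfanyl on an aromatic carbon, and its size cannot be read, because of the limit of < 20% in this assay, at which 1 of the 2 values shown sits.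

Compound 3 `CC(=O)Nc1ccc(/C(C)=N/OCC(=O)O)cc1` differs from compound 2 by acetyl in place of hydrogen on a nitrogen on an aromatic ring. Within the data shown here, no measured step exchanges a hydrogen on that nitrogen, so the single step from compound 1 to compound 2 bears only loosely on this change, and its size is open. Nothing in the numbers shown points to a step beyond the usual scatter in either direction.

The step from compound 2 to compound 3 in this assay is therefore expected to be a number 5 percentage points higher from compound 2 to compound 3 (within the scatter). Compound 3 is estimated at 25% in this assay, with a range from 5% to 50%.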

Compound 3, a percentage reported as inhibition, in the whole organism at one dose (the size of the read-out at that dose, not a potency): < 20%
Compound 3: only a limit was reported; the forecaster's own chance of this, stated with the estimate: 35%; at least 5 percentage points between middle value and limit.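

Acetyl in place of hydrogen on the nitrogen on the aromatic ring gives a number no higher from compound 2 to compound 3 (the limit leaves the size open) in this assay, the first change shown on that nitrogen itself. Compound 3 gives < 20%, which is a limit of the assay and not a number. Amino to acetamido therefore leaves compound 2 as the only entry with a number, while the acetamido and methylsulfanyl groups both end at a limit, and neither the size of any step at this position nor any order between them can be read: the limit of < 20% in this assay, at which 2 of the 3 values shown sit.

Open, on these data alone, is whether the amino group of compound 2 really stands apart from the groups in compound 1 and compound 3, or whether all three lie close together. Also open, as far as these compounds go, is whether a longer acyl chain on this nitrogen, or a dimethylamino group or a carboxylic acid in place of the amino group on the aromatic carbon, would give a number in this assay.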